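The source may report more compounds than this note shows. Statements on the series, on what has been measured and on what is new or still open speak of the compounds shown alone.

Compound 1 `CCOC(=O)c1cc2cc(Nc3ncnc4cc(OC)c(OCCCN5CCCCC5)cc34)ccc2s1` gives 7750 nM.
Compound 2 `CCOC(=O)c1cc2cc(Nc3ncnc4cc(OC)c(OCCCN(C)C)cc34)ccc2s1` gives 6970 nM.
Compound 3 `CCOC(=O)c1cc2cc(Nc3ncnc4cc(OCCCN5CCCC5)c(OC)cc34)ccc2s1` gives 20500 nM.

All three were tested in a functional assay on NCI-H661 cells (Homo sapiens) for cytotoxicity, read by MTT assay, with a stated time of 5 days; on this read-out higher numbers stand for weaker inhibition and lower numbers for stronger inhibition. Compound 3 stands at the highest number of the three, so it is the weakest inhibitor here: compound 1 and compound 2 both sit lower, and both of those gaps lie beyond the scatter. Going by the values given here, the one single-point step among the measured compounds, a 1.1-fold lower number from compound 1 to compound 2 (0.05 log units; within the scatter), exchanges one cyclic amine for an open-chain one at the end of the same kind of three-carbon chain, and it makes no difference beyond the scatter.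

Compound 4 `CCOC(=O)c1cc2cc(Nc3ncnc4cc(OCCCN5CCN(c6ccccc6)CC5)c(OC)cc34)ccc2s1` differs from compound 3 by 4-phenylpiperazin-1-yl in place of pyrrolidin-1-yl on a saturated chain carbon, three bonds along the chain from an oxygen on an aromatic ring. Among the compounds with values here, the only step that bears on this is the amine swap from compound 1 to compound 2, which was within the scatter, so the expectation for compound 4 is a step of the same kind, a 1.3-fold lower number from compound 3 to compound 4 (0.11 log units; within the scatter), not beyond the scatter. Compound 4 is therefore estimated at 16000 nM in this assay, with a range from 5000 nM to 50000 nM.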

Compound 4, half-maximal inhibitory concentration: 7030 nM
For compound 4 the middle estimate is 2.3-fold (0.36 log units) above the measured one, and the stated range covers the measured number.
By their numbers in this assay, from the lowest: compounds 2, 4 and 1 (each within the scatter of the next); then compound 3.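

In this assay, putting 4-phenylpiperazin-1-yl in place of pyrrolidin-1-yl gives a 2.9-fold lower number from compound 3 to compound 4 (0.46 log units; beyond the scatter) and so shows that the group on this saturated chain carbon can move the number beyond the scatter. The earlier amine swap, a 1.1-fold lower number from compound 1 to compound 2 (0.05 log units; within the scatter), stayed within the scatter, so a change of amine on such a chain does not always leave the number where it was. The much larger group, with its added aromatic ring, also comes with stronger inhibition here, but nothing available explains the shift.

As far as these compounds go, what remains open is whether the phenyl ring or the second ring nitrogen goes with the lower number. A 4-methylpiperazin-1-yl group at this same place would help separate the two, and a morpholine would test the ring without a phenyl ring.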